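A few compounds are considered here, and "the series" means these few. Any claim that something is new, unique, unknown or untested is made for them only; others in the source may bear on it.

Compound 1 `CC1CCN(c2ccc(Nc3nccc(-c4cccnc4)n3)cc2)CC1` is tested in a functional assay for inhibition, with Homo sapiens as the target (a lower number here means a stronger inhibitor, a higher number a weaker inhibitor), where compound 1 gives 500 nM. Among the three compounds measured, this is the second highest number: compound 2 `CC1CCN(c2ccc(Nc3nccc(-c4cccs4)n3)cc2)CC1` gives 400 nM, and compound 3 `Cc1cccc(Nc2nccc(-c3ccc[nH]3)n2)c1` gives 8500 nM. Among the compounds with values here, the only single change measured, a 1.3-fold lower number from compound 1 to compound 2 (0.10 log units; within the scatter), swaps the heteroaromatic group on the other end of the shared core and lies within the scatter. Compound 4 `CN(C)c1ccc(Nc2nccc(-c3cccnc3)n2)cc1` differs from compound 1 at a different point: dimethylamino in place of 4-methylpiperidin-1-yl on an aromatic carbon. Within the data shown here, no measured step touches this group, so the direction is uncertain. Compound 3, which carries no such amine at all, stands far weaker at 8500 nM, and a smaller amine in compound 4 might give up part of that advantage. Compound 4 is therefore expected to give 1000 nM, between 300 nM and 3500 nM, corresponding to a 2.0-fold higher number from compound 1 to compound 4 (0.30 log units; within the scatter).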

Compound 4, half-maximal inhibitory concentration: 2800 nM
Beside the measured number, compound 4's estimate is 2.8-fold (0.45 log units) below it; low and high end bracket the measured number.
By their numbers in this assay, from the lowest: compounds 2 and 1 (each within the scatter of the next); then compound 4; then compound 3.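

Putting dimethylamino in place of 4-methylpiperidin-1-yl gives a 5.6-fold higher number from compound 1 to compound 4 (0.75 log units; beyond the scatter) and so shows that this position can shift the number beyond the scatter, which the earlier single change did not show. The entering group has no ring and 3 heavy atoms, against 7 in the group that leaves, and here the inhibitor is weaker. Nothing available explains this loss. Going by these compounds, whether the ring or the group's size matters more remains open. Diethylamino, which has no ring, or a morpholine ring at this position could help separate the two.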